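Furan-2-yl methyl in place of fluoro-methoxybenzyl on shared core

The compounds below may be only part of what the source reports. "The series", "measured", "known", "first", "only" and "open" are said of these compounds alone.

In a physicochemical assay for acid dissociation, compound 2 `COc1cccc(Oc2ccc3c(NCCCNCc4cc(F)ccc4OC)ccnc3c2)c1` gives 9.28, one of two numbers that lie within the scatter of each other. In this assay compound 1 `CC(C)Cc1ccc2c(NCCCNCc3ccco3)ccnc2c1` gives 9.47. The step from compound 2 to compound 3 `COc1cccc(Oc2ccc3c(NCCCNCc4ccco4)ccnc3c2)c1` is furan-2-yl in place of 5-fluoro-2-methoxyphenyl on a saturated chain carbon bound to an amine nitrogen. Within the data shown here, no measured pair covers this change; compound 1 already carries the (furan-2-yl)methyl group on a different core and its value sits close to compound 2, so no movement beyond the scatter is expected. Compound 3 is therefore estimated at 9.4, range 9.15 to 9.65. The expected step is a number 0.12 log units higher from compound 2 to compound 3 (within the scatter), inside the scatter.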

Compound 3, acid dissociation constant: 9.28
The estimate for compound 3 lay 0.12 log units above the measured number, and the stated range covers the measured number.
By their numbers in this assay, from the lowest: compounds 2, 3 and 1 (each within the scatter of the next).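

In this assay, the furan-2-yl for 5-fluoro-2-methoxyphenyl change on a saturated chain carbon bound to an amine nitrogen gives no change at the digits printed from compound 2 to compound 3 (within the scatter) as a direct pair on the shared core. With (furan-2-yl)methyl held fixed, 3-methoxyphenoxy in place of isobutyl on an aromatic carbon gives a number 0.19 log units lower from compound 1 to compound 3 (within the scatter), so neither change moves the number beyond the scatter. No evidence bears on the cause of either result.

Open: whether a pyridin-2-yl group or a carboxylic acid on that chain carbon would leave the number within the scatter of compound 3 too.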